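Series notes: a methyl gives way to a methylsulfonyl group

This account rests on a few compounds, and the source may have more. Where it says the series, first, only, none or still open, it means among the compounds named here.

In an assay for inhibition of Tryptophan 2,3-dioxygenase (Homo sapiens), with stated times of 10 min and 60 min, tested at 10 uM (a lower number here means a weaker effect, a higher number a stronger effect of the compound at the concentration tested), compound 1 `O=[N+]([O-])c1cccc(CNc2cc(C(F)(F)F)cc3[nH]ncc23)c1` gives 60%. Compound 2 `Cc1ccc(CNc2cc(C(F)(F)F)cc3[nH]ncc23)c([N+](=O)O)c1` gives 90% in this assay. Of these two numbers compound 2 stands highest; compound 1 is its nearest neighbour and sits lower by a gap that lies beyond the usual scatter of repeated measurements. Within the data shown here, no step between measured compounds that differ in a single place is available, so the two values can only be read side by side, and nothing ties the gap to any one change in structure.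

Compound 3 `CS(=O)(=O)c1ccc(CNc2cc(C(F)(F)F)cc3[nH]ncc23)c([N+](=O)O)c1` has not been measured in this assay. Against compound 2 it differs in one place: methylsulfonyl in place of methyl on an aromatic carbon. Among the measured compounds shown here, no measured pair shows this change, so its size cannot be taken from the numbers at hand. In this assay the step is expected to be a number 20 percentage points lower from compound 2 to compound 3 (beyond the scatter), a modest loss, with a broad range on either side because no measured value constrains it. Compound 3 is estimated at 70% in this assay, within a range from 35% to 95%.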

Compound 3, a percentage reported as inhibition, at one concentration (the size of the read-out at that concentration, not a potency): 96%
Estimate against measurement, compound 3: 26 percentage points below; measured number outside the range, above it.
By their numbers in this assay, from the lowest: compound 1; then compounds 2 and 3 (each within the scatter of the next).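

In this assay, a number 6 percentage points higher from compound 2 to compound 3 (within the scatter), so this aromatic carbon, para to a large group and meta to a group of 3 heavy atoms, takes methylsulfonyl in place of methyl with no step beyond the scatter. The change is not small by count: 4 heavy atoms with 2 hydrogen-bond acceptors enter where 1 heavy atom with 0 hydrogen-bond acceptors leaves, yet the read-out does not separate the two compounds. No data at hand bear on why the two read-outs stand together.

Both read-outs are percentages at a single concentration and show only the size of the effect at that concentration, so how compound 2 and compound 3 compare at other concentrations remains unresolved. Also open, on these data alone, is how far this position accepts other groups, such as an amine, a carboxylic acid or a longer chain such as ethylsulfonyl, and whether methylsulfonyl gives a similar step when the rest of the compound is changed.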